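The source may report more compounds than this note shows. Statements on the series, on what has been measured and on what is new or still open speak of the compounds shown alone.

Measured so far in a functional assay on MCF7 cells (Homo sapiens) for inhibition, read by MTT assay, with stated times of 18 h and 4 h; on this read-out higher numbers stand for weaker inhibition and lower numbers for stronger inhibition:
- Compound 1 `CCCCCCCCCCCCCCCCOP(=O)(O)OCCSC(=S)N1CCN(C)CC1`: > 100000 nM (a limit, not a number)
- Compound 2 `CCCCCCCCOP(=O)(O)OCCSC(=S)N1CCN(C)CC1`: 46000 nM
- Compound 3 `CCCCCCOP(=O)(O)OCCSC(=S)N1CCCC1`: 100000 nM

Only two of these are true numbers. Compound 3 gives 100000 nM, the higher of the two, and compound 2, the nearest, gives 46000 nM, a gap beyond the usual scatter.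

The next compound, compound 4 `CCCCCCOP(=O)(O)OCCSC(=S)N1CCN(C)CC1`, keeps the chain of compound 3 and changes one group: 4-methylpiperazin-1-yl in place of pyrrolidin-1-yl on a thiocarbonyl carbon.

Within the data shown here, no measured step makes this swap. Among the measured compounds shown here, the only measured step, an at least 2.1-fold lower number from compound 1 to compound 2 (0.33 log units; beyond the scatter), alters the chain instead, so it bears on the swap only indirectly. Its size also rests on a limit, (the limit of > 100000 nM in this assay, at which 1 of the 3 values shown sits).

The best guide is compound 2, which carries the same 4-methylpiperazin-1-yl and gives 46000 nM. In this assay, a small fall in the number is therefore expected, a 1.7-fold lower number from compound 3 to compound 4 (0.22 log units; within the scatter), and this expected step would not clearly exceed the scatter. Compound 4 is estimated at 60000 nM, with an expected range from 25000 nM to 120000 nM.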

Compound 4, half-maximal inhibitory concentration: 58000 nM
Compound 4: the middle estimate sits 1.0-fold (0.01 log units) above what was measured; measured number inside the range.
By their numbers in this assay, from the lowest: compounds 2, 4 and 3 (each within the scatter of the next, the first and the last beyond it).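

In this assay, among these compounds, this is the first direct look at 4-methylpiperazin-1-yl in place of pyrrolidin-1-yl on the thiocarbonyl carbon, and with the chain held fixed, the swap gives a 1.7-fold lower number from compound 3 to compound 4 (0.24 log units; within the scatter), so the two rings cannot be told apart here. With 4-methylpiperazin-1-yl kept in place, the ethyl difference in the chain gives a 1.3-fold higher number from compound 2 to compound 4 (0.10 log units; within the scatter), so these two chain lengths cannot be told apart in this assay either. Compound 1 carries a limit, not a number, so an at least 1.7-fold lower number from compound 1 to compound 4 (0.23 log units; that floor lies within the scatter) sets only a floor and cannot show how far the hexadecyl compound lies from the others: the limit of > 100000 nM in this assay, at which 1 of the 4 values shown sits.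

The compounds shown leave open whether another ring on the thiocarbonyl carbon, such as morpholin-4-yl or piperidin-1-yl, would give a number clearly apart from these. They also leave open how pyrrolidin-1-yl would read when paired with an octyl chain, and where a decyl or dodecyl chain would fall on the way to the limit seen with the hexadecyl chain.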